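Methyl for hydrogen on two different nitrogens

A few compounds are considered here, and "the series" means these few. Any claim that something is new, unique, unknown or untested is made for them only; others in the source may bear on it.

Compound 1 `CNCC1CCCc2cc(S(=O)(=O)c3ccccc3)ccc21` gives 0.316 nM in an assay on isolated protein for displacement of a labelled ligand from 5-hydroxytryptamine receptor 6 (Homo sapiens); a higher number here means a weaker inhibitor, a lower number a stronger inhibitor. Compound 2 `CN(C)CC1CCCc2cc(S(=O)(=O)c3ccccc3)ccc21` gives 0.0631 nM in this assay, and the step of a 5.0-fold lower number from compound 1 to compound 2 (0.70 log units; beyond the scatter) comes from one change: methyl in place of hydrogen on an amine nitrogen

Compound 3 `CNS(=O)(=O)NC[C@@H]1CCCc2cc(S(=O)(=O)c3cccc(F)c3)ccc21` gives 1 nM in this assay, the highest number among the three measured compounds. How its core differs from the core of compound 1 is not broken down here. Compound 4 `CN(C)S(=O)(=O)NC[C@@H]1CCCc2cc(S(=O)(=O)c3cccc(F)c3)ccc21` is not yet measured; it differs from compound 3 in one place: methyl in place of hydrogen on a sulfonamide nitrogen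

The change is the same kind of change as that from compound 1 to compound 2, but not the same: in compound 1 the nitrogen is an amine nitrogen whose other neighbours are saturated chain carbon and saturated chain carbon, whereas in compound 3 it is a sulfonamide nitrogen whose other neighbours are saturated chain carbon and sulfonyl sulfur. Because the earlier step of a 5.0-fold lower number from compound 1 to compound 2 (0.70 log units; beyond the scatter) was made on an amine nitrogen, a smaller step is expected here, a 1.7-fold lower number from compound 3 to compound 4 (0.22 log units; within the scatter). For compound 4 in this assay the estimate is 0.6 nM, expected to lie between 0.2 nM and 2 nM.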

Compound 4, inhibition constant: 2 nM
Compound 4: middle estimate off by 3.3-fold (0.52 log units), on the low side; low and high end bracket the measured number.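

Methyl in place of hydrogen on a sulfonamide nitrogen gives a 2.0-fold higher number from compound 3 to compound 4 (0.30 log units; within the scatter) in this assay, so on this core the two compounds cannot be told apart. Set beside the step on the amine nitrogen, the same kind of change does not carry over from one core to the other with the same size: the same change on two cores in this assay, a 5.0-fold lower number (0.70 log units; beyond the scatter) from compound 1 to compound 2 and a 2.0-fold higher number (0.30 log units; within the scatter) from compound 3 to compound 4, 10-fold (1.00 log units) apart, beyond the scatter of two such steps This rests on one pair of compounds on each core, and those cores differ in more than the kind of nitrogen that takes the methyl, so it does not show which difference matters, nor does it give a rule for the series.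

The compounds shown leave open whether a methyl on an amine nitrogen would give the earlier step on a core that carries the fluorine. They also leave open how an ethyl group on the sulfonamide nitrogen, or an amide in place of the sulfonamide, would read in this assay.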